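A New Phenyl Group on the Shared Core

A few compounds are considered here, and "the series" means these few. Any claim that something is new, unique, unknown or untested is made for them only; others in the source may bear on it.

- compound 1 `Cc1oc(-c2ccc(F)cc2)nc1CN1CCC(C(=O)NCCCN2C[C@H](C)C[C@H](C)C2)CC1`: 0.468 h
- compound 2 `Cc1cccc(F)c1-c1nc(CN2CCC(C(=O)NCCCN3C[C@H](C)C[C@H](C)C3)CC2)c(C)o1`: 0.0733 h
- compound 3 `COc1cccc(Br)c1-c1nc(CN2CCC(C(=O)NCCCN3C[C@H](C)C[C@H](C)C3)CC2)c(C)o1`: 0.0583 h

In an ADME assay on microsomes from liver (Rattus norvegicus) for metabolic stability, read by LC-MS, using NADPH, at 37 degrees C (a lower number here means that the compound disappears faster, a higher number that the compound lasts longer), compound 3 stands at the low end of the three numbers, and the scatter does not separate it from its nearest neighbour, with a 1.3-fold lower number from compound 2 to compound 3 (0.10 log units; within the scatter). Far above both lies the third compound, with an 8.0-fold lower number from compound 1 to compound 3 (0.90 log units; beyond the scatter) and a 6.4-fold lower number from compound 1 to compound 2 (0.81 log units; beyond the scatter).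

Compound 4 `CCc1ccccc1-c1nc(CN2CCC(C(=O)NCCCN3C[C@H](C)C[C@H](C)C3)CC2)c(C)o1` follows from 2-ethylphenyl in place of 2-bromo-6-methoxyphenyl on an aromatic carbon. Like compound 2 and compound 3, it lacks the 4-fluorophenyl of compound 1, so the small step is the closest guide, and no change beyond the scatter is expected in this assay. The expected step is a 1.4-fold higher number from compound 3 to compound 4 (0.14 log units; within the scatter). Compound 4 is estimated at 0.08 h, with an expected range of 0.04 h to 0.2 h.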

Compound 4, half-life: 0.283 h
Estimate against measurement, compound 4: 3.5-fold (0.55 log units) below; measured number outside the range, above it.
By their numbers in this assay, from the lowest: compounds 3 and 2 (each within the scatter of the next); then compounds 4 and 1 (each within the scatter of the next).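

In this assay, 2-ethylphenyl gives a 4.9-fold higher number from compound 3 to compound 4 (0.69 log units; beyond the scatter) and a 3.9-fold higher number from compound 2 to compound 4 (0.59 log units; beyond the scatter), so at this position a phenyl group other than the 4-fluorophenyl of compound 1 does not always go with the short half-lives of compound 2 and compound 3. With a 1.7-fold lower number from compound 1 to compound 4 (0.22 log units; within the scatter), the scatter does not separate 2-ethylphenyl from 4-fluorophenyl here. The compounds shown leave open what a longer chain such as propyl in place of the ethyl, or an amine on the phenyl ring, would give. No measured evidence here explains the size of these steps.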